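Swapping bromine for a methoxyphenyl ring

The compounds below may be only part of what the source reports. "The series", "measured", "known", "first", "only" and "open" are said of these compounds alone.

Of the compounds shown here, two sharing one core have been tested. Compound 1 `COc1ccc(-c2cn(Cc3ccc(F)cc3)c(=O)c(C(=O)NC3CCCCCC3)c2C)cc1` reaches only the limit of > 10000 nM in an assay on HEK293 cells for inhibition of Monoacylglycerol lipase ABHD6 (Homo sapiens), with stated times of 30 min and 5 min (on this read-out lower numbers stand for stronger inhibition and higher numbers for weaker inhibition), so no number is known for it. For the measured compounds named here, compound 2 `O=C(NC1CCCCCC1)c1c(-c2ccccc2)c(Br)cn(Cc2ccc(F)cc2)c1=O` gives 3000 nM in this assay and is therefore the only compound with a measured value. Compound 3 `COc1ccc(-c2cn(Cc3ccc(F)cc3)c(=O)c(C(=O)NC3CCCCCC3)c2-c2ccccc2)cc1` has not been tested yet; it differs from compound 2 by 4-methoxyphenyl in place of bromo on an aromatic carbon. Because compound 1, which also carries a 4-methoxyphenyl group, gives only the limit > 10000 nM, a weakening step is expected for a 2.7-fold higher number from compound 2 to compound 3 (0.43 log units; beyond the scatter). Compound 3 is therefore estimated at 8000 nM, likely between 2000 nM and 30000 nM.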

Compound 3, half-maximal inhibitory concentration: > 10000 nM
Compound 3: a limit, no number; the forecaster's own chance of this, stated with the estimate: 40%; middle value at least 1.2-fold (0.09 log units) from the limit.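

On this aromatic carbon, 4-methoxyphenyl in place of bromo gives an at least 3.3-fold higher number from compound 2 to compound 3 (0.52 log units; beyond the scatter), so this exchange does not keep even the modest inhibition seen with bromo. Compound 3 stands at a limit, not a number: the limit of > 10000 nM in this assay, at which 2 of the 3 values shown sit. The step from compound 1 to compound 3 cannot be read.

On these data alone, it remains open how chlorine, an amine or a carboxylic acid on this carbon would compare with bromo. Also open, as far as these compounds go, is whether a plain phenyl group here, without the methoxy, would behave like 4-methoxyphenyl.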